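Nitrile to Pyridine: Expected Cytotoxicity of Compound 4

The source may hold more compounds than are shown below. What is called first, only, known or untested is meant among the compounds shown, and "the series" means these compounds.

Compound 1 `COC(=O)N[C@H](C(=O)NN(CCC[C@@](O)(Cc1ccccc1)C(=O)N[C@H]1c2ccccc2C[C@H]1O)Cc1ccc(F)cc1)C(C)(C)C` in an ADME assay on MT4 cells (Homo sapiens) for cytotoxicity (on this read-out lower numbers stand for higher toxicity in this test and higher numbers for lower toxicity in this test), gives > 10000 nM, a limit of the assay.
Compound 2 `COC(=O)N[C@H](C(=O)NN(CCC[C@@](O)(Cc1ccccc1)C(=O)N[C@H]1c2ccccc2C[C@H]1O)Cc1ccc(C#N)cc1)C(C)(C)C` in this assay gives > 10000 nM, also a limit.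
Compound 3 `COC(=O)N[C@H](C(=O)NN(CCC[C@@](O)(Cc1ccccc1)C(=O)N[C@H]1c2ccccc2C[C@H]1O)Cc1ccc(-c2nc(C(C)(C)C)cs2)cc1)C(C)(C)C` in this assay gives > 10000 nM, again a limit.

Compound 2 therefore stands only at a limit in this assay, and the two other values are limits as well, so no order among the three compounds can be read. Compound 4 `COC(=O)N[C@H](C(=O)NN(CCC[C@@](O)(Cc1ccccc1)C(=O)N[C@H]1c2ccccc2C[C@H]1O)Cc1ccc(-c2ccncc2)cc1)C(C)(C)C` differs from compound 2 by pyridin-4-yl in place of cyano on an aromatic carbon. The measured steps bearing on this change, a step that the two limits leave unreadable from compound 1 to compound 2, a step that the two limits leave unreadable from compound 1 to compound 3 and a step that the two limits leave unreadable from compound 2 to compound 3, are all unreadable because of the limit of > 10000 nM in this assay, at which 3 of the 3 values shown sit. Three different groups at this position, including the 4-(tert-butyl)-1,3-thiazol-2-yl group, leave the result beyond the limit, so for compound 4 no step beyond the scatter is expected in this assay, and the estimated step is a step that the limit leaves unreadable from compound 2 to compound 4. Compound 4 is expected to give 15000 nM, within 6000 nM to 50000 nM, most likely reported again as a limit.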

Compound 4, half-maximal cytotoxic concentration: > 10000 nM
Compound 4: a limit, no number (the forecaster's own chance of this, stated with the estimate: 85%); the middle value is on the limit's open side.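

No step from compound 1, compound 2 or compound 3 to compound 4 can be read in this assay, because each value is a limit and not a number: the limit of > 10000 nM in this assay, at which 4 of the 4 values shown sit.

The compounds shown leave open how far apart these four compounds lie, and whether swapping the group on the aromatic ring changes cytotoxicity at all.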